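This account rests on a few compounds, and the source may have more. Where it says the series, first, only, none or still open, it means among the compounds named here.

The compounds measured so far in a functional assay on DU-145 cells (Homo sapiens) for cytotoxicity, read by trypan blue exclusion, with a stated time of 96 h (a lower number here means a stronger inhibitor, a higher number a weaker inhibitor), are these:

- compound 1 `COc1ccc(CS(=O)(=O)/C=C/c2ccccc2OC)cc1N` gives 7500 nM
- compound 2 `COc1ccc(CS(=O)(=O)/C=C/c2c(OC)cccc2OC)c([N+](=O)[O-])c1` gives 50000 nM
- compound 3 `COc1ccc(CS(=O)(=O)/C=C/c2c(OC)cccc2OC)c(N)c1` gives 750 nM

Compound 2 has the highest number of the three, and both other compounds lie lower, beyond the scatter. Compound 4 `COc1cc(OC)c(/C=C/S(=O)(=O)Cc2ccc(OC)cc2[N+](=O)[O-])c(OC)c1` differs from compound 2 in one place: methoxy in place of hydrogen on an aromatic carbon. This is methoxy in place of hydrogen on an aromatic carbon, meta to two methoxy groups and para to a large group.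

Among the measured compounds shown here, the only measured single change is a large one, a 67-fold lower number from compound 2 to compound 3 (1.82 log units; beyond the scatter), with amino in place of nitro on an aromatic carbon. For the measured compounds named here, compound 4 keeps the nitro, so this step says little about it, and no measured pair shows the new change directly. Compound 2 already stands at the top of the range (50000 nM), so a moderate move to a lower number in this assay is expected rather than a rise, though it may not clear the scatter. The expected change is a 3.3-fold lower number from compound 2 to compound 4 (0.52 log units; beyond the scatter). For compound 4 the estimated value is 15000 nM, with an expected range from 2500 nM to 60000 nM.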

Compound 4, half-maximal inhibitory concentration: 20000 nM
Compound 4: the middle estimate sits 1.3-fold (0.12 log units) below what was measured; measured number inside the range.
By their numbers in this assay, from the lowest: compound 3; then compound 1; then compound 4; then compound 2.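

In this assay, methoxy in place of hydrogen on the aromatic carbon meta to two methoxy groups and para to a large group gives a 2.5-fold lower number from compound 2 to compound 4 (0.40 log units; beyond the scatter). This shows that the position accepts a methoxy group with a modest gain while the nitro stays in place, although this step is much smaller than a 67-fold lower number from compound 2 to compound 3 (1.82 log units; beyond the scatter), the step for amino in place of nitro. Nothing measured here explains the gain from the added methoxy.

The compounds shown leave open whether the added methoxy would also lower the number in the amino compound 3, which gives 750 nM. They also leave open whether the gain is particular to methoxy, or whether a fluorine, a hydroxy group or a longer ethoxy chain on the same carbon would give a similar step.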